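The source may report more compounds than this note shows. Statements on the series, on what has been measured and on what is new or still open speak of the compounds shown alone.

Three compounds built on one shared core have been run in an ADME assay on Raji cells (Homo sapiens) for inhibition, with a stated time of 72 h; on this read-out lower numbers stand for an effect already at smaller amounts and higher numbers for an effect only at larger amounts of compound. Compound 1 `C=C(C)C(=O)Nc1cccc(-c2nc3ccccc3s2)c1` bears a 1-methylethenyl group on the carbonyl carbon, and in this assay compound 1 gives only a limit, > 25000 nM. Compound 2 `CN(C)CCC(=O)Nc1cccc(-c2nc3ccccc3s2)c1` bears a 2-(dimethylamino)ethyl group in that place, and in this assay compound 2 likewise gives only a limit, > 25000 nM. Compound 3 `CC(Cl)C(=O)Nc1cccc(-c2nc3ccccc3s2)c1` bears a 1-chloroethyl group there, and in this assay compound 3 also gives only a limit, > 25000 nM. Because the limit of > 25000 nM in this assay, at which 3 of the 3 values shown sit, none of the steps among them can be read: a step that the two limits leave unreadable from compound 1 to compound 2, a step that the two limits leave unreadable from compound 1 to compound 3 and a step that the two limits leave unreadable from compound 2 to compound 3 all remain of unknown size. Compound 3 therefore stands at the limit together with the other two, and nothing orders it among them.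

Compound 4 `CC(C)(CCl)C(=O)Nc1cccc(-c2nc3ccccc3s2)c1` differs from compound 3 in one place: 1-(chloromethyl)-1-methylethyl in place of 1-chloroethyl on a carbonyl carbon. The measured steps bear on this change only in that every variation on the carbonyl carbon so far has ended at the same limit, and they give no readable size to set against the new group. The expectation for the step that the limit leaves unreadable from compound 3 to compound 4 is accordingly a change of no size beyond the scatter. Compound 4 is therefore expected to reach only the limit again, with an estimate in this assay of 30000 nM and a range from 10000 nM to 100000 nM.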

Compound 4, half-maximal effective concentration: > 25000 nM
Compound 4 was reported as a limit; the forecaster's own chance of this, stated with the estimate: 80%; the middle value does not contradict the limit.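

Compound 4 ends at the same limit as compound 1, compound 2 and compound 3, so none of the steps from those compounds to compound 4 can be read in this assay: the limit of > 25000 nM in this assay, at which 4 of the 4 values shown sit.

The compounds shown leave open whether any group on the carbonyl carbon of the shared core gives a measurable effect in this assay, and how the four compounds rank among themselves.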